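The source may hold more compounds than are shown below. What is called first, only, known or untested is meant among the compounds shown, and "the series" means these compounds.

In a functional assay for inhibition, with Homo sapiens as the target (on this read-out higher numbers stand for weaker binding and lower numbers for tighter binding), three related compounds have been measured so far. Compound 1 `O=C(O)CC/C=C\CC1COC(c2ccsc2)OC1c1cccnc1` gives 1580 nM, compound 2 `O=C(O)CC/C=C\CC1COC(c2cccc3ccccc23)OC1c1cccnc1` gives 631 nM, and compound 3 `Cc1ccc(C#N)c(OC(C)(C)C2OCC(C/C=C\CCC(=O)O)C(c3cccnc3)O2)c1` gives 15.9 nM, the lowest number of the three and so the tightest binding.

Still unmeasured is compound 4 `CSc1ccccc1OC(C)(C)C1OCC(C/C=C\CCC(=O)O)C(c2cccnc2)O1`, which differs from compound 3 in one group: 2-(methylsulfanyl)phenyl in place of 2-cyano-5-methylphenyl on an oxygen on a saturated carbon. Put simply, 2-(methylsulfanyl)phenyl stands in place of 2-cyano-5-methylphenyl on an oxygen on a saturated carbon. Both groups hold one six-membered aromatic ring of carbon only.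

Among the measured compounds shown here, only one measured step offers a guide: a 2.5-fold lower number from compound 1 to compound 2 (0.40 log units; beyond the scatter), where naphthalen-1-yl replaced thiophen-3-yl on a saturated ring carbon. That step was modest, but it lies at a different place in the molecule, so it bears on this swap only loosely. For the measured compounds named here, no measured compound carries the entering group, so the data do not settle the direction.

A modest step of similar size is expected in this assay, with a higher number judged somewhat likelier than a lower one. The estimated change is a 2.5-fold higher number from compound 3 to compound 4 (0.40 log units; beyond the scatter). For compound 4 the expected value is 40 nM, with an estimated range from 10 nM to 150 nM.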

Compound 4, dissociation constant: 89.1 nM
The estimate for compound 4 lay 2.2-fold (0.35 log units) below the measured number; the range from low to high includes it.
By their numbers in this assay, from the lowest: compound 3; then compound 4; then compound 2; then compound 1.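

In this assay the swap of 2-cyano-5-methylphenyl for 2-(methylsulfanyl)phenyl on an oxygen on a saturated carbon gives a 5.6-fold higher number from compound 3 to compound 4 (0.75 log units; beyond the scatter) and so shows that this position responds to the choice of group, even though both groups hold one six-membered aromatic ring of carbon only. The ring type alone therefore does not set the number here, and what is attached to the ring also counts. The swap changes several things at once, since the leaving group has a nitrile and a methyl while the entering group has a methylsulfanyl with its sulfur, and nothing available explains why the number moved.

On these data alone, it stays open whether the nitrile, the methyl or the methylsulfanyl matters most, and how a ring carrying a methoxy group or a chlorine atom would compare at this place. Also open, as far as these compounds go, is whether the same swap would shift the number by a similar amount in a compound with an amide in place of the carboxylic acid.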